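Replacing azidomethyl with diethylcarbamoyl on the shared core

The compounds below may be only part of what the source reports. "The series", "measured", "known", "first", "only" and "open" are said of these compounds alone.

In a functional assay on MCF7 cells (Homo sapiens) for antiproliferative activity, read by MTT assay, with a stated time of 48 h (on this read-out lower numbers stand for stronger inhibition and higher numbers for weaker inhibition), compound 1 (`COC/C1=C/C[C@](C)(CCC=C(C)C)/C=C/[C@@H](OC(=O)C=C(C)C)[C@](C)(O)/C=C/C1=O`) gives 4130 nM and compound 2 (`CC(C)=CCC[C@]1(C)/C=C/[C@@H](OC(=O)C=C(C)C)[C@](C)(O)/C=C/C(=O)/C(CN(C)C)=C\C1`) gives 690 nM while compound 3 (`CC(C)=CCC[C@]1(C)/C=C/[C@@H](OC(=O)C=C(C)C)[C@](C)(O)/C=C/C(=O)/C(CN=[N+]=[N-])=C\C1`) gives 4890 nM so compound 3 sits level with compound 1 and well clear of compound 2. Compound 4 (`CCN(CC)C(=O)/C1=C/C[C@](C)(CCC=C(C)C)/C=C/[C@@H](OC(=O)C=C(C)C)[C@](C)(O)/C=C/C1=O`) carries diethylcarbamoyl in place of azidomethyl on a double-bonded ring carbon. Among the compounds with values here, no measured compound carries diethylcarbamoyl, so the measured steps bear on this change only indirectly. The swap from methoxy to azido, a 1.2-fold higher number from compound 1 to compound 3 (0.07 log units; within the scatter) stays within the scatter. Only the dimethylamino group of compound 2 moved the number beyond it, in the modest steps of a 6.0-fold lower number from compound 1 to compound 2 (0.78 log units; beyond the scatter) and a 7.1-fold higher number from compound 2 to compound 3 (0.85 log units; beyond the scatter) and compound 4 does not carry that group. In this assay the expected step is therefore none beyond the scatter, namely a 1.2-fold lower number from compound 3 to compound 4 (0.09 log units; within the scatter) but the uncertainty is wide. Compound 4 is estimated at 4000 nM (expected range from 1500 nM to 10000 nM).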

Compound 4, half-maximal inhibitory concentration: 12100 nM
For compound 4 the middle estimate is 3.0-fold (0.48 log units) below the measured one; the measured number lies above the stated range.
By their numbers in this assay, from the lowest: compound 2; then compounds 1 and 3 (each within the scatter of the next); then compound 4.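

In this assay this position now moves the number upward too: a 2.5-fold higher number from compound 3 to compound 4 (0.39 log units; beyond the scatter) and a 2.9-fold higher number from compound 1 to compound 4 (0.47 log units; beyond the scatter) both lie beyond the scatter, whereas the methoxymethyl and azidomethyl compounds had stood level. The range at this one ring carbon also widens, with an 18-fold higher number from compound 2 to compound 4 (1.24 log units; beyond the scatter) now a large step, and compound 4 is the weakest of the four. A nitrogen in the group is thus not enough for the lower number: compound 3 and compound 4 both carry one, and only compound 2 goes lower.

Nothing given here explains these differences. The compounds shown leave open whether the rise goes with the carbonyl on the ring carbon or with the ethyl groups, and a (diethylamino)methyl group or a carboxylic acid at this place would bear on that question.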